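The compounds below may be only part of what the source reports. "The series", "measured", "known", "first", "only" and "open" are said of these compounds alone.

In a functional assay on MDA-MB-231 cells (Homo sapiens) for inhibition, read by CCK-8 assay, with a stated time of 48 h (a higher number here means a weaker inhibitor of growth, a lower number a stronger inhibitor of growth), compound 1 `Cc1ccc(CNc2nc(Nc3ccc(N4CCN(C)CC4)cn3)ncc2Cl)cc1` gives 18600 nM and compound 3 `COc1ccc(CNc2nc(Nc3ccc(N4CCN(C)CC4)cn3)ncc2Cl)cc1` gives 14900 nM as a value within the scatter of compound 1. Compound 2 `CN1CCN(c2ccc(Nc3ncc(Cl)c(NCc4ccc(F)cc4)n3)nc2)CC1` gives > 100000 nM as a limit of the assay, not a number. Compound 4 `COc1cccc(CNc2nc(Nc3ccc(N4CCN(C)CC4)cn3)ncc2Cl)c1` has the same atoms as compound 3, joined differently: 3-methoxyphenyl in place of 4-methoxyphenyl (3-methoxyphenyl in place of 4-methoxyphenyl on a saturated chain carbon bound to a nitrogen on an aromatic ring). For the measured compounds named here, no measured step shows this kind of change, so the nearest guides are swaps of the group itself. The swap a 1.2-fold lower number from compound 1 to compound 3 (0.10 log units; within the scatter) stays within the scatter, whereas an at least 6.7-fold lower number from compound 2 to compound 3 (0.82 log units; beyond the scatter) goes beyond it and rests on the limit of compound 2. Compound 4 keeps the methoxy group, so the expected size is a 1.1-fold higher number from compound 3 to compound 4 (0.03 log units; within the scatter) and no more than the scatter. Compound 4 is estimated at about 16000 nM with an expected range from 6000 nM to 45000 nM in this assay testing.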

Compound 4, concentration for 50% growth inhibition: 20300 nM
Compound 4: middle estimate off by 1.3-fold (0.10 log units), on the low side, and the stated range covers the measured number.
By their numbers in this assay, from the lowest: compounds 3, 1 and 4 (each within the scatter of the next). At a limit, above all of these: compound 2.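

In this assay, 3-methoxyphenyl and 4-methoxyphenyl cannot be told apart: a 1.4-fold higher number from compound 3 to compound 4 (0.13 log units; within the scatter). The 3-methoxyphenyl of compound 4 also stays level with the 4-methylphenyl of compound 1: a 1.1-fold higher number from compound 1 to compound 4 (0.04 log units; within the scatter). Only the comparison with 4-fluorophenyl stands out, an at least 4.9-fold lower number from compound 2 to compound 4 (0.69 log units; beyond the scatter), and it rests on a limit of compound 2, not a number: the limit of > 100000 nM in this assay, at which 1 of the 4 values shown sits.

The compounds shown leave open whether an amine or a carboxylic acid in place of the methoxy group would move the number beyond the scatter. They also leave open what a longer chain between the ring and the amino nitrogen would do.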